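The compounds below may be only part of what the source reports. "The series", "measured", "known", "first", "only" and "open" are said of these compounds alone.

Measured so far:
compound 1 `CN(Cc1nc(C2CCN(Cc3ccccc3)CC2)no1)c1ncc(/C=C/C(=O)NO)cn1`: 547 nM
compound 2 `CN(Cc1nc(C2CCN(Cc3ccccc3)CC2)no1)c1ncc(C(=O)NO)cn1`: 27.6 nM
compound 3 `Cc1cccc(CN2CCC(c3noc(CN(C)c4ncc(C(=O)NO)cn4)n3)CC2)c1`: 47.3 nM

All three were tested in a functional assay on Raji cells (Homo sapiens) for antiproliferative activity, read by MTT assay, with a stated time of 72 h; a lower number here means a stronger inhibitor, a higher number a weaker inhibitor. There compound 3 gives 47.3 nM. Among the compounds with values here, that number is far lower than the one for compound 1 at 547 nM, and it lies within the usual scatter of compound 2 at 27.6 nM.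

The next compound, compound 4 `CN(Cc1nc(C2CCN(Cc3ccc(F)cc3)CC2)no1)c1ncc(C(=O)NO)cn1`, keeps the shared core and carries 4-fluorophenyl in place of 3-methylphenyl on a saturated chain carbon bound to an amine nitrogen in a ring.

Two measured steps are available as guides. The change a 20-fold lower number from compound 1 to compound 2 (1.30 log units; beyond the scatter) was large, but it concerned the hydroxycarbamoyl end of the molecule, so it says little about this change. The closer guide is a 1.7-fold higher number from compound 2 to compound 3 (0.23 log units; within the scatter), which put methyl in place of hydrogen on an aromatic carbon of the group that now changes again, and it stayed within the scatter. Within the data shown here, no fluorine-bearing compound has been measured yet, so the data cannot show what fluorine does here.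

The expectation in this assay is therefore no step beyond the scatter. The expected change is a 1.4-fold lower number from compound 3 to compound 4 (0.13 log units; within the scatter), which would stay within the scatter. For compound 4 the estimated value is 35 nM, with an expected range from 14 nM to 90 nM.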

Compound 4, half-maximal inhibitory concentration: 22 nM
Estimate against measurement, compound 4: 1.6-fold (0.20 log units) above; low and high end bracket the measured number.
By their numbers in this assay, from the lowest: compounds 4, 2 and 3 (each within the scatter of the next, the first and the last beyond it); then compound 1.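

In this assay, within the data shown here, the swap of 3-methylphenyl for 4-fluorophenyl gives a 2.2-fold lower number from compound 3 to compound 4 (0.33 log units; beyond the scatter), the first step at this position that passes the scatter, though only modestly. Fluoro in place of hydrogen on its own gives a 1.3-fold lower number from compound 2 to compound 4 (0.10 log units; within the scatter), which stays within the scatter, so compound 2 does not separate from compound 4 and this position carries a fluoro without any measurable change from the bare phenyl ring. Among these compounds, the gap between compound 3 and compound 4 is thus the only difference at this position beyond the scatter, and compound 2 lies within the scatter of both, so the position so far shows a narrow spread; no measurement here offers a reason for either step.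

The swap removes a methyl and adds a fluoro at once, so the compounds shown cannot tell which of the two accounts for the gap, or what either group would do at another place on the ring. Also open, on these data alone, is how this position responds to groups of a different kind, such as a methoxy, a chloro or an amine on the phenyl ring, or a cyclohexyl ring in place of the phenyl.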